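Methoxy in Place of Hydrogen: Compound 3 to Compound 4

A few compounds are considered here, and "the series" means these few. Any claim that something is new, unique, unknown or untested is made for them only; others in the source may bear on it.

Compound 1 `C=CCn1nc(Cc2ccc(OC)cc2)c2ccccc2c1=O` and compound 2 `CCn1nc(Cc2ccc(OC)cc2)c2ccccc2c1=O` carry no result in a functional assay on aorta with Alpha-1D adrenergic receptor (Rattus norvegicus) as the target; on this read-out lower numbers stand for an effect already at smaller amounts and higher numbers for an effect only at larger amounts of compound: for compound 1 the entry reads "not determined" (no result reported), and for compound 2 it reads "not determined" (no result reported). For the measured compounds named here, compound 3 `Cn1nc(Cc2ccccc2)c2ccccc2c1=O` is the only member with a reported entry, and that entry is a limit of this assay: in this assay compound 3 gives <= 10000 nM, which is the limit of <= 10000 nM in this assay, at which 1 of the 3 values shown sits. Going by the values given here, no step between measured compounds exists, so compound 3 stands alone. Compound 4 `COc1ccc(Cc2nn(C)c(=O)c3ccccc23)cc1` differs from compound 3 by methoxy in place of hydrogen on an aromatic carbon. With only a limit as anchor, the expected step is a step that the limit leaves unreadable from compound 3 to compound 4, in no direction beyond the scatter. Compound 4 is estimated at 3000 nM in this assay, within 500 nM to 10000 nM.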

Compound 4, half-maximal effective concentration: < 100000 nM
Compound 4: only a limit was reported (the forecaster's own chance of this, stated with the estimate: 50%); the middle value lies beyond the limit too.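

For the compounds shown here, compound 3 and compound 4 both carry only limits in this assay, so no step between them can be read. The compounds shown leave open whether methoxy in place of hydrogen on an aromatic carbon shifts this read-out at all, and in which direction.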